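Shortening the linker while bringing back the chloro group

A few compounds are considered here, and "the series" means these few. Any claim that something is new, unique, unknown or untested is made for them only; others in the source may bear on it.

Compound 2 `c1ccc2c(c1)CC2CCCN1CCN(c2cccc3c2OCCO3)CC1` stands with the lowest number among the two compounds measured in a functional assay on the whole organism for antagonist activity, with Rattus norvegicus as the target (a higher number here means that more compound is needed for the effect, a lower number that less compound is needed), giving 0.16 mg/kg. Its nearest neighbour is compound 1 `Clc1cccc2c1CC2CCCN1CCN(c2cccc3c2OCCO3)CC1`, which gives 0.63 mg/kg in this assay; the difference between them is a 3.9-fold lower number from compound 1 to compound 2 (0.60 log units; beyond the scatter). Compound 3 `Clc1cccc2c1CC2CCN1CCN(c2cccc3c2OCCO3)CC1` has not yet been measured. The change from compound 2 to compound 3 is a group of 9 heavy atoms (8 carbon, 1 chlorine; one four-membered non-aromatic ring of carbon only, one six-membered aromatic ring of carbon only) in place of a group of 9 heavy atoms (9 carbon; one four-membered non-aromatic ring of carbon only, one six-membered aromatic ring of carbon only), on a saturated chain carbon, two bonds along the chain from an amine nitrogen in a ring. Within the data shown here, the only measured step that bears on this is the one from compound 1 to compound 2, where removing the chloro group lowered the number by a modest amount beyond the scatter; compound 3 reverses that removal, so the number is expected to rise again by about the same amount, while the other part of the change has no measured counterpart here. Compound 3 is therefore estimated at 0.63 mg/kg in this assay, with a range of 0.2 mg/kg to 2 mg/kg, which would be a step of a 3.9-fold higher number from compound 2 to compound 3 (0.60 log units; beyond the scatter).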

Compound 3, minimum effective dose: 1.25 mg/kg
Compound 3: the middle estimate sits 2.0-fold (0.30 log units) below what was measured; measured number inside the range.
By their numbers in this assay, from the lowest: compound 2; then compounds 1 and 3 (each within the scatter of the next).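

In this assay, the step of a 7.8-fold higher number from compound 2 to compound 3 (0.89 log units; beyond the scatter) brings in the chloro group and the shorter chain together, so on its own it cannot show how much each change contributes. Compound 1 and compound 3 both carry the chloro group and differ only in the chain: compound 1 gives 0.63 mg/kg and compound 3 gives 1.25 mg/kg, values within the scatter of each other, so shortening the chain produces no readable change when the chloro group is present. No measurement shown here gives a reason for these numbers.

From the compounds shown here alone, the shorter chain without the chloro group remains open, so it is unclear whether chain length matters in that setting. Also open, going by these compounds, are a longer chain and a fluoro or methyl group in place of the chloro group.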